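Swapping a methylsulfanyl for a carboxyphenyl on the shared core

A few compounds are considered here, and "the series" means these few. Any claim that something is new, unique, unknown or untested is made for them only; others in the source may bear on it.

Of the compounds shown here, three built on one core have been measured so far. Compound 1 `CCCCCCCCc1ccc(OCC(=O)Cn2nnc(-c3ccccc3Cl)n2)cc1` gives 32 nM in an assay on microsomes from brain for inhibition of Fatty-acid amide hydrolase 1 (Rattus norvegicus), read by fluorescence and HPLC, with a stated time of 60 min (on this read-out higher numbers stand for weaker inhibition and lower numbers for stronger inhibition), and compound 2 `CCCCCCCCc1ccc(OCC(=O)Cn2nnc(-c3cccc(C(=O)O)c3)n2)cc1` gives 36 nM. Compound 3 `CCCCCCCCc1ccc(OCC(=O)Cn2nnnc2SC)cc1` gives 22 nM, the lowest of the three numbers, though its gaps to compound 1 and to compound 2 both lie within the scatter, so nothing separates the three in strength.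

The next compound, compound 4 `CCCCCCCCc1ccc(OCC(=O)Cn2nnnc2-c2cccc(C(=O)O)c2)cc1`, keeps the core of compound 3 and changes one place: 3-carboxyphenyl in place of methylsulfanyl on an aromatic carbon. The new group sits on an aromatic carbon of a five-membered aromatic ring with 4 nitrogen.

Going by the values given here, one measured step bears on this. In a 1.1-fold higher number from compound 1 to compound 2 (0.05 log units; within the scatter) a 3-carboxyphenyl took the place of another aryl group on an aromatic carbon of the same kind of ring, and the number barely moved. That says the 3-carboxyphenyl is tolerated there. Among the compounds with values here, no measured step, however, trades a methylsulfanyl for an aryl group, so the exchange in compound 4 is only partly covered.

On that basis compound 4 is expected to show a 1.4-fold higher number from compound 3 to compound 4 (0.13 log units; within the scatter), a step no larger than the scatter. The estimate for compound 4 in this assay is 30 nM, with a range from 12 nM to 80 nM.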

Compound 4, half-maximal inhibitory concentration: 1800 nM
For compound 4 the middle estimate is 60-fold (1.78 log units) below the measured one; measured number above the stated range.
By their numbers in this assay, from the lowest: compounds 3, 1 and 2 (each within the scatter of the next); then compound 4.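

Going by these compounds alone, this position on the core of compound 3 is far less forgiving than the earlier compounds suggested: in this assay, putting 3-carboxyphenyl in place of methylsulfanyl gives an 82-fold higher number from compound 3 to compound 4 (1.91 log units; beyond the scatter), the first change in this set to lie beyond the scatter. The same 3-carboxyphenyl made no clear difference in the step of a 1.1-fold higher number from compound 1 to compound 2 (0.05 log units; within the scatter), so its acceptance on the core of compound 1 did not carry over to the core of compound 3, and a step measured on one of these cores cannot be assumed to hold on the other. Nothing among the available data explains why this exchange costs so much inhibition.

Two things change together in this step, an aromatic ring of carbon arrives and a carboxylic acid arrives with it, and the compounds shown cannot separate them. An unsubstituted phenyl or the methyl ester of the acid at this same aromatic carbon would show whether the drop follows the ring or the acid, and a small group such as methyl would show how much of the methylsulfanyl is needed at all.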